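Replacing the oxetanyloxy group with a fluorocyclobutyl on the carbonyl

The compounds below may be only part of what the source reports. "The series", "measured", "known", "first", "only" and "open" are said of these compounds alone.

Three compounds share a core and differ only at the group attached to the carbonyl carbon of the ring nitrogen. In a functional assay on isolated protein for inhibition of Glucose-dependent insulinotropic receptor (Homo sapiens), read by HTRF and cAMP accumulation (a higher number here means that more compound is needed for the effect, a lower number that less compound is needed), compound 1 `Cc1nc(S(C)(=O)=O)ccc1Oc1ncnc(OC2CCN(C(=O)OC(C)C)CC2)c1F` gives 21 nM, compound 2 `Cc1nc(S(C)(=O)=O)ccc1Oc1ncnc(OC2CCN(C(=O)OC(C)F)CC2)c1F` gives 65.5 nM, and compound 3 `Cc1nc(S(C)(=O)=O)ccc1Oc1ncnc(OC2CCN(C(=O)OC3(C(F)(F)F)COC3)CC2)c1F` gives 29.3 nM. Compound 3 thus holds the second highest of the three numbers: its nearest neighbour is compound 1, with a 1.4-fold higher number from compound 1 to compound 3 (0.14 log units; within the scatter), while the furthest is compound 2, with a 2.2-fold lower number from compound 2 to compound 3 (0.35 log units; beyond the scatter).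

Compound 4 `Cc1nc(S(C)(=O)=O)ccc1Oc1ncnc(OC2CCN(C(=O)C3(F)CCC3)CC2)c1F` carries a different change: a group of 5 heavy atoms (4 carbon, 1 fluorine; one four-membered non-aromatic ring of carbon only) in place of a group of 9 heavy atoms (4 carbon, 2 oxygen, 3 fluorine; one four-membered non-aromatic ring with 1 hetero atom), on a carbonyl carbon. The measured steps all concern the group on the oxygen next to the carbonyl, and none of them removes that oxygen; the steps seen are a 3.1-fold higher number from compound 1 to compound 2 (0.49 log units; beyond the scatter) and a 1.4-fold higher number from compound 1 to compound 3 (0.14 log units; within the scatter). Those steps are modest or within the scatter, so the change to compound 4 is expected to give at most a modest step in this assay, in no certain direction. Compound 4 is therefore expected to give 35 nM, within a range of 12 nM to 100 nM, which corresponds to an expected 1.2-fold higher number from compound 3 to compound 4 (0.08 log units; within the scatter).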

Compound 4, half-maximal effective concentration: 24.7 nM
For compound 4 the middle estimate is 1.4-fold (0.15 log units) above the measured one; low and high end bracket the measured number.
By their numbers in this assay, from the lowest: compounds 1, 4 and 3 (each within the scatter of the next); then compound 2.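

In this assay, the oxygen on the carbonyl carbon proves dispensable, which none of the earlier changes could show: exchanging the (3-(trifluoromethyl)oxetan-3-yl)oxy group for the fluorine-bearing four-membered carbon ring gives a 1.2-fold lower number from compound 3 to compound 4 (0.07 log units; within the scatter), and the comparison with the isopropyl carbamate gives a 1.2-fold higher number from compound 1 to compound 4 (0.07 log units; within the scatter). The 1-fluoroethyl carbamate alone stands apart, with a 2.7-fold lower number from compound 2 to compound 4 (0.42 log units; beyond the scatter). No evidence is at hand on why this exchange is tolerated.

From the compounds shown here alone, what the fluorine on the new ring contributes remains open, and an unsubstituted cyclobutyl group on the carbonyl carbon would address that. Also open, going by these compounds, is whether an amine on the carbonyl carbon, such as dimethylamino, would fit this position as well.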